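A few compounds are considered here, and "the series" means these few. Any claim that something is new, unique, unknown or untested is made for them only; others in the source may bear on it.

Measured compounds:
compound 1 `Fc1ccc(Cc2ccc3c(NCCCNCc4ccco4)ccnc3c2)c(Cl)c1` — 23 10^-6 cm/s
compound 2 `COc1ccc(F)cc1CNCCCNc1ccnc2cc(Cc3ccc(F)cc3Cl)ccc12` — 23 10^-6 cm/s
compound 3 `COc1cccc(CNCCCNc2ccnc3cc(Cc4ccc(F)cc4Cl)ccc23)c1O` — 23 10^-6 cm/s

In an ADME assay for permeability, using PAMPA, with a stated time of 30 min, at pH 7.4 (on this read-out higher numbers stand for higher permeability and lower numbers for lower permeability), compound 1 stands level with compounds 2 and 3 at the digits shown. The nearest is compound 2, with no change at the digits printed from compound 1 to compound 2 (within the scatter); the furthest is compound 3, with no change at the digits printed from compound 1 to compound 3 (within the scatter). Between the two of them the read-out is likewise flat, no change at the digits printed from compound 2 to compound 3 (within the scatter). All three measured steps sit on a saturated chain carbon bound to an amine nitrogen, where three quite different aryl groups leave this assay unchanged.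

Compound 4 `c1ccc(Cc2ccc3c(NCCCNCc4ccco4)ccnc3c2)cc1` differs from compound 1 in another place: phenyl in place of 2-chloro-4-fluorophenyl on a saturated chain carbon bound to an aromatic carbon. Among the measured compounds shown here, no measured step touches this position, so nothing measured bears on it directly; the only guidance is that every change tried so far, no change at the digits printed from compound 1 to compound 2 (within the scatter) and no change at the digits printed from compound 1 to compound 3 (within the scatter) included, left this assay within the scatter. On that basis the expected step is a 1.2-fold lower number from compound 1 to compound 4 (0.06 log units; within the scatter), with no change beyond the scatter anticipated. Compound 4 is therefore estimated at 20 10^-6 cm/s, with an expected range from 10 10^-6 cm/s to 35 10^-6 cm/s.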

Compound 4, apparent permeability: 23 10^-6 cm/s
Estimate against measurement, compound 4: 1.2-fold (0.06 log units) below, and the stated range covers the measured number.
By their numbers in this assay, from the lowest: compounds 1, 2, 3 and 4 (each within the scatter of the next).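

Phenyl in place of 2-chloro-4-fluorophenyl on a saturated chain carbon bound to an aromatic carbon gives, in this assay, no change at the digits printed from compound 1 to compound 4 (within the scatter), so a second place in the molecule now has a measured step and it is as flat as the three steps at the amine end. This one step removes the chlorine and the fluorine together, so neither halogen is read alone. No measurement here accounts for the flat read-out.

Among the compounds shown here, whether a carboxylic acid or an amine in place of the phenyl would shift this assay beyond the scatter remains open, since every group at this place so far is a carbon-only aromatic ring. Also open, from the compounds shown here alone, is whether phenyl combined with 5-fluoro-2-methoxyphenyl or 2-hydroxy-3-methoxyphenyl at the amine end would read the same.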